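Methoxy additions in a series sitting at the assay limit

A few compounds are considered here, and "the series" means these few. Any claim that something is new, unique, unknown or untested is made for them only; others in the source may bear on it.

Compound 1 `COc1ccc(CNc2ncnc3c2ncn3C2CCCCO2)cc1OC` and compound 2 `COc1cc(OC)c(OC)cc1CNc1ncnc2c1ncn2C1CCCCO1` share one core. In an ADME assay on K562 cells (Homo sapiens) for cytotoxicity, with a stated time of 72 h (a lower number here means a stronger inhibitor, a higher number a weaker inhibitor), compound 1 gives only a limit, > 100000 nM. Compound 2 likewise gives only a limit in this assay, > 100000 nM. The change of methoxy in place of hydrogen on an aromatic carbon therefore yields a step that the two limits leave unreadable from compound 1 to compound 2. Compound 3 `COc1ccc(CNc2ncnc3c2ncn3C2CCCO2)cc1` has a core whose difference from compound 1 is not broken down here. In this assay compound 3 gives only a limit, > 100000 nM. Compound 4 `COc1ccc(CNc2ncnc3c2ncn3C2CCCO2)c(OC)c1` differs from compound 3 by methoxy in place of hydrogen on an aromatic carbon, the same kind of change as from compound 1 to compound 2, though there the place is also para to a methoxy group. Going by the values given here, because every value so far sits at the limit of > 100000 nM in this assay, at which 3 of the 3 values shown sit, compound 4 is expected to stay at that limit, with an expected step that the limit leaves unreadable from compound 3 to compound 4. The estimate for compound 4 is 150000 nM, between 50000 nM and 500000 nM.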

Compound 4, half-maximal inhibitory concentration: > 100000 nM
Compound 4 was reported as a limit; the forecaster's own chance of this, stated with the estimate: 85%; the middle value does not contradict the limit.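

No step from compound 3 to compound 4 can be read in this assay, as both values are limits: the limit of > 100000 nM in this assay, at which 4 of the 4 values shown sit.

The compounds shown leave open what a methoxy addition does to cytotoxicity, with no value inside the readable range.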